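This account rests on a few compounds, and the source may have more. Where it says the series, first, only, none or still open, it means among the compounds named here.

Measured in an ADME assay on liver (Rattus norvegicus, strain Wistar) for metabolic stability, read by HPLC, tested at 200 uM; a lower number here means that the compound disappears faster, a higher number that the compound lasts longer:
Compound 1 `Cc1cc(OC(=O)OCCCCCCO[N+](=O)[O-])n(-c2ccccc2)n1`: < 0.0167 h
Compound 2 `Cc1cc(OC(=O)OCCCCC(CO[N+](=O)[O-])O[N+](=O)[O-])n(-c2ccccc2)n1`: < 0.0167 h
Compound 3 `Cc1cc(OC(=O)C(C)(C)CO[N+](=O)[O-])n(-c2ccccc2)n1`: < 0.0167 h

Compound 1 gives < 0.0167 h, and this is a limit of the assay and not a number. The entries for compound 2 and compound 3 are limits too, so no ranking can be read from this set.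

Compound 4 `Cc1cc(OC(=O)OCCCO[N+](=O)[O-])n(-c2ccccc2)n1` is built from compound 1 by one change on the chain. It carries nitrooxy in place of 3-(nitrooxy)propyl on a saturated chain carbon, three bonds along the chain from an oxygen next to a carbonyl group.

Going by the values given here, the only measured step on this chain is a step that the two limits leave unreadable from compound 1 to compound 2, so it offers no size to carry over. The broader picture is the limit of < 0.0167 h in this assay, at which 3 of the 3 values shown sit. With nothing in the data pointing either way, the expected change is a step that the limit leaves unreadable from compound 1 to compound 4, with none beyond the usual scatter and no direction foreseen.

The assay will quite likely report only a limit again. For compound 4 the estimated half-life is 0.012 h, with an expected range from 0.005 h to 0.03 h.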

Compound 4, half-life in the liver assay: < 0.0167 h
Compound 4 gave a limit, no number; the forecaster's own chance of this, stated with the estimate: 85%; the middle value is on the limit's open side.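

In the liver assay compound 1 gives < 0.0167 h, and this is a limit of the assay and not a number. In the liver assay compound 4 gives < 0.0167 h, which is also a limit of the assay and not a number. Going by these compounds alone, compound 1 and compound 4 both return only a limit in the liver assay, and no step between them can be read. The compounds shown leave open how long any of them actually lasts in the liver assay, and whether the change from compound 1 to compound 4 makes any difference there. In a physicochemical assay for metabolic stability, read by HPLC (a lower number here means that the compound disappears faster, a higher number that the compound lasts longer), compound 1 gives 4 h and compound 4 gives 1.4 h. In the physicochemical assay this is a 2.9-fold lower number from compound 1 to compound 4 (0.46 log units; beyond the scatter).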